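Thiophene for furan on the biaryl position

The source may report more compounds than this note shows. Statements on the series, on what has been measured and on what is new or still open speak of the compounds shown alone.

Compound 2 `COc1ccc(S(=O)(=O)N2CCc3cccc(-c4ccco4)c32)cc1` holds the lowest number of the three measured in a functional assay on HT-29 cells (Homo sapiens) for inhibition, with a stated time of 72 h (a higher number here means a weaker inhibitor, a lower number a stronger inhibitor), giving 62.5 nM. Compound 1 `COc1ccc(S(=O)(=O)N2CCc3cccc(-c4ccc(N)cc4)c32)cc1` gives 301 nM and compound 3 `COc1ccc(S(=O)(=O)N2CCc3cccc(-c4cccc(F)c4)c32)cc1` gives 119 nM; the step of a 4.8-fold lower number from compound 1 to compound 2 (0.68 log units; beyond the scatter) lies beyond the scatter, whereas the step of a 1.9-fold higher number from compound 2 to compound 3 (0.28 log units; within the scatter) does not. Compound 4 `COc1ccc(S(=O)(=O)N2CCc3cccc(-c4cccs4)c32)cc1` differs from compound 2 only in one change: thiophen-2-yl in place of furan-2-yl on an aromatic carbon. Among the compounds with values here, no measured step exchanges one five-membered aromatic ring for another, so the nearest guide is the step of a 1.9-fold higher number from compound 2 to compound 3 (0.28 log units; within the scatter), which stayed within the scatter. The expected step of a 1.1-fold higher number from compound 2 to compound 4 (0.05 log units; within the scatter) is therefore none beyond the scatter. Compound 4 is estimated at 70 nM, with a range from 30 nM to 160 nM.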

Compound 4, half-maximal inhibitory concentration: 200 nM
The estimate for compound 4 lay 2.9-fold (0.46 log units) below the measured number; measured number outside the range, above it.
By their numbers in this assay, from the lowest: compounds 2, 3, 4 and 1 (each within the scatter of the next, the first and the last beyond it).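

In this assay this position distinguishes two five-membered aromatic rings: thiophen-2-yl in place of furan-2-yl gives a 3.2-fold higher number from compound 2 to compound 4 (0.51 log units; beyond the scatter) even though both groups have the same counts of heavy atoms, donors and acceptors. The other steps, a 1.7-fold higher number from compound 3 to compound 4 (0.23 log units; within the scatter) and a 1.5-fold lower number from compound 1 to compound 4 (0.18 log units; within the scatter), both stay within the scatter, so compound 4 is not separated from either phenyl-bearing compound. Nothing available explains the difference between the furan-2-yl and thiophen-2-yl groups. Still open, as far as these compounds go, is how a thiazole or pyrrole ring would compare with furan-2-yl here, and whether a methyl group on the furan-2-yl ring would preserve the number seen for compound 2.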